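Fluoro for hydrogen on the shared core: distribution notes

The source may report more compounds than this note shows. Statements on the series, on what has been measured and on what is new or still open speak of the compounds shown alone.

Compound 1 `O=C1[C@@H](NS(=O)(=O)c2ccc3cc(Cl)ccc3c2)CCN1c1ccc2c(c1)CCNC2` is the reference. In an in vivo ADME assay on the whole organism (strain Sprague-Dawley) for pharmacokinetics, with Rattus norvegicus as the target (a higher number here means that more of the compound sits outside the plasma, a lower number that more of the compound stays in the plasma), compound 1 gives 3.6 L/kg. Compound 3 `O=C1[C@@H](NS(=O)(=O)c2ccc3cc(Cl)ccc3c2)CCN1c1ccc2c(c1F)CCNC2` carries the change (fluoro in place of hydrogen on an aromatic carbon); in this assay compound 3 gives 2.4 L/kg, and the step is a 1.5-fold lower number from compound 1 to compound 3 (0.18 log units; within the scatter). Compound 2 `O=C1[C@@H](NS(=O)(=O)c2ccc3c(Cl)c[nH]c3c2)CCN1c1ccc2c(c1)CCNC2` has a different core from compound 1; the difference between the two cores is not broken down here. In this assay compound 2 gives 2.9 L/kg, which sits within the scatter of both compound 1 and compound 3.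

Compound 4 `O=C1[C@@H](NS(=O)(=O)c2ccc3c(Cl)c[nH]c3c2)CCN1c1cc2c(cc1F)CNCC2` is not yet measured. It stands to compound 2 as compound 3 stands to compound 1, by the change (fluoro in place of hydrogen on an aromatic carbon). The surroundings differ: in compound 3 the fluoro is ortho to a fused ring and meta to a fused ring, in compound 4 it is meta to a fused ring and para to a fused ring, so this is the same kind of change rather than the same change. The expected step from compound 2 to compound 4 is a 1.3-fold lower number from compound 2 to compound 4 (0.12 log units; within the scatter), resting on compound 1 to compound 3 with its a 1.5-fold lower number from compound 1 to compound 3 (0.18 log units; within the scatter). Compound 4 is therefore estimated at 2.2 L/kg, with the range 1.2 L/kg to 3.8 L/kg.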

Compound 4, volume of distribution at steady state: 0.5 L/kg
For compound 4 the middle estimate is 4.4-fold (0.64 log units) above the measured one; the measured number lies below the stated range.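

Fluoro in place of hydrogen on an aromatic carbon gives a 5.8-fold lower number from compound 2 to compound 4 (0.76 log units; beyond the scatter) in this assay, so the size of the step seen on the core of compound 1 does not carry over to the core of compound 2: the same change on two cores in this assay, a 1.5-fold lower number (0.18 log units; within the scatter) from compound 1 to compound 3 and a 5.8-fold lower number (0.76 log units; beyond the scatter) from compound 2 to compound 4, 3.9-fold (0.59 log units) apart, beyond the scatter of two such steps

Going by these compounds alone, only the step on the core of compound 2 lies beyond the scatter, so these two pairs do not establish a shared direction for the change. The fluoro in compound 4 is ortho to a large group, meta to a fused ring and para to a fused ring, surroundings that differ from those in compound 3, so the pairs cannot separate the role of the core from that of the fluoro's place, and they give no cause for the gap.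

Still open, on these data alone, is whether fluoro in the same surroundings on both cores would give steps of like size. Also open, as far as these compounds go, is whether a methyl or a nitrile in place of that hydrogen in compound 2 would give a step like a 5.8-fold lower number from compound 2 to compound 4 (0.76 log units; beyond the scatter).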